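A Smaller Amine Arm on a Shared Core

The source may hold more compounds than are shown below. What is called first, only, known or untested is meant among the compounds shown, and "the series" means these compounds.

Compound 1 `CCCN(CCC(F)(F)F)Cc1c(C(F)(F)F)nc2n(-c3c(C)cc(C)cc3C)c(Cl)cn12` gives 12 nM in an assay on cells for displacement of a labelled ligand from corticotropin-releasing factor receptor 1 (Homo sapiens), with a stated time of 100 min; on this read-out higher numbers stand for weaker inhibition and lower numbers for stronger inhibition. Compound 2 `Cc1cc(C)c(-n2c(Cl)cn3c(CN(CCC(F)(F)F)Cc4ccc(Cl)cc4)c(C(F)(F)F)nc23)c(C)c1` gives 12 nM, so compound 1 stands level with it, and the step of no change at the digits printed from compound 1 to compound 2 (within the scatter) lies within the scatter. Compound 3 `Cc1cc(C)c(-n2c(Cl)cn3c(CN(C)Cc4ccco4)c(C(F)(F)F)nc23)c(C)c1` differs from compound 1 by ((furan-2-yl)methyl)(methyl)amino in place of propyl(3,3,3-trifluoropropyl)amino on a saturated chain carbon bound to an aromatic carbon. For the measured compounds named here, only the step from compound 1 to compound 2 bears on this; it altered the same amine yet kept the trifluoropropyl arm that now leaves. For compound 3 a modest weakening is expected, a step of a 2.1-fold higher number from compound 1 to compound 3 (0.32 log units; beyond the scatter). Compound 3 is therefore estimated at 25 nM, within 8 nM to 80 nM.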

Compound 3, inhibition constant: 180 nM
Beside the measured number, compound 3's estimate is 7.2-fold (0.86 log units) below it, and the stated range ends below it.
By their numbers in this assay, from the lowest: compounds 1 and 2 (each within the scatter of the next); then compound 3.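

The amine on this saturated chain carbon does not accept every change: ((furan-2-yl)methyl)(methyl)amino in place of propyl(3,3,3-trifluoropropyl)amino gives a 15-fold higher number from compound 1 to compound 3 (1.18 log units; beyond the scatter) in this assay. The earlier step, no change at the digits printed from compound 1 to compound 2 (within the scatter), kept the trifluoropropyl arm, whereas this one replaces both arms of the amine. Nothing measured here explains the loss.

With both arms replaced together, the methyl, the furan ring and the missing trifluoropropyl arm cannot be told apart. As far as these compounds go, whether a butyl chain on the amine would hold the number stays open.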